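This account rests on a few compounds, and the source may have more. Where it says the series, first, only, none or still open, it means among the compounds named here.

Three closely related compounds have numbers in a physicochemical assay for lipophilicity, read by HPLC, in phosphate buffer, measured as octanol-water partition, with a stated time of 1 h, at pH 7.4; on this read-out lower numbers stand for lower lipophilicity and higher numbers for higher lipophilicity. Compound 1 `N#Cc1ccc(C(=O)Nc2ccc(F)c([C@]3(C4CC4)C=C(CF)OC(N)=N3)c2)nc1` gives 2.9, and compound 3 `C[C@@]1(c2cc(NC(=O)c3cnc(OCF)cn3)ccc2F)C=C(CF)OC(N)=N1` gives 2.6. Compound 2 `COCC1=C[C@@](C)(c2cc(NC(=O)c3ccc(C#N)cn3)ccc2F)N=C(N)O1` gives 2, the lowest of the three, and its gaps to compound 3 and to compound 1 both lie beyond the usual scatter of repeated measurements.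

Compound 4 `CC1=C[C@@](C)(c2cc(NC(=O)c3ccc(C#N)cn3)ccc2F)N=C(N)O1` has no number yet in this assay. It differs from compound 2 in a single place: hydrogen in place of methoxy on a saturated chain carbon bound to a double-bonded ring carbon. Put simply, hydrogen stands in place of methoxy on a saturated chain carbon bound to a double-bonded ring carbon, so that methoxymethyl becomes methyl.

For the measured compounds named here, none of the measured compounds differ from each other in only one place, so the data offer no direct measure of this change, and the three numbers mainly show the range in which this family has been seen so far. The expectation therefore rests on the structural change alone: a modest rise in this assay, a little beyond the scatter, though a step within the scatter cannot be ruled out. Starting from compound 2 at 2, the estimated step is a number 0.40 log units higher from compound 2 to compound 4 (beyond the scatter). For compound 4 the expected value is 2.4, with an estimated range from 2 to 2.8.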

Compound 4, distribution coefficient: 2.2
Beside the measured number, compound 4's estimate is 0.20 log units above it, within the range that was stated.
By their numbers in this assay, from the lowest: compounds 2 and 4 (each within the scatter of the next); then compounds 3 and 1 (each within the scatter of the next).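

For the compounds shown here, this pair gives the first direct reading of a single change in this assay: with hydrogen in place of methoxy on a saturated chain carbon bound to a double-bonded ring carbon, turning methoxymethyl into methyl, the result is a number 0.20 log units higher from compound 2 to compound 4 (within the scatter). At this position, then, removing methoxy, with its 2 heavy atoms and 1 hydrogen-bond acceptor, leaves a difference that repeated measurements alone could produce, so compound 2 and compound 4 cannot be told apart on this read-out. No measurement shown here offers an explanation for this result.

Going by these compounds alone, this is still only one pair, so it remains open whether the same change would read alike with different groups elsewhere on the shared core. As far as these compounds go, it is also open whether other groups at this place, such as an aminomethyl group, a carboxylic acid or a longer chain like propyl, would stay within the scatter of methyl and methoxymethyl or move clearly away from them.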